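A few compounds are considered here, and "the series" means these few. Any claim that something is new, unique, unknown or untested is made for them only; others in the source may bear on it.

Compound 3 `Cc1cccc(-c2c(C)nn(-c3nc(-c4ccc(Cl)c(Cl)c4)c(SC(C)C)s3)c2C(=O)O)c1` gives the highest number of the three measured compounds in a functional assay on BJAB cells (Homo sapiens) for antiproliferative activity, with a stated time of 4 days (on this read-out lower numbers stand for an effect already at smaller amounts and higher numbers for an effect only at larger amounts of compound), at 17000 nM. Compound 1 `Cc1nn(-c2nc(-c3ccc(Cl)c(Cl)c3)c(SC(C)C)s2)c(C(=O)O)c1-c1ccc(Cl)cc1` gives 2500 nM in this assay, and compound 2 `Cc1nn(-c2nc(-c3ccc(Cl)c(Cl)c3)c(SC(C)C)s2)c(C(=O)O)c1-c1cccc(Cl)c1C` gives 5100 nM. Both steps into compound 3 raised the number: a 6.8-fold higher number from compound 1 to compound 3 (0.83 log units; beyond the scatter) and a 3.3-fold higher number from compound 2 to compound 3 (0.52 log units; beyond the scatter), while the step of a 2.0-fold higher number from compound 1 to compound 2 (0.31 log units; beyond the scatter) was smaller. Compound 4 `CCOc1ncccc1-c1c(C)nn(-c2nc(-c3ccc(Cl)c(Cl)c3)c(SC(C)C)s2)c1C(=O)O` differs from compound 3 at the same aromatic carbon: 2-ethoxypyridin-3-yl in place of 3-methylphenyl on an aromatic carbon. The three measured steps all exchange the aryl group at this position and show that such exchanges move this assay by a modest amount in either direction. Going by the values given here, no measured step places a pyridine ring or an ethoxy group there, so the direction for compound 4 is not fixed by the data. Compound 3 already sits at the top of the measured spread. The expected step of a 1.9-fold lower number from compound 3 to compound 4 (0.28 log units; within the scatter) for compound 4 is therefore small, with room to either side. Compound 4 is expected to give 9000 nM in this assay, in a range from 2500 nM to 30000 nM.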

Compound 4, half-maximal effective concentration: 11000 nM
The estimate for compound 4 lay 1.2-fold (0.09 log units) below the measured number; low and high end bracket the measured number.
By their numbers in this assay, from the lowest: compound 1; then compound 2; then compounds 4 and 3 (each within the scatter of the next).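

In this assay, the step of a 1.5-fold lower number from compound 3 to compound 4 (0.19 log units; within the scatter) shows that a pyridine ring with an ethoxy group, bringing 2 hydrogen-bond acceptors, is accommodated at this aromatic carbon without separating from 3-methylphenyl. The same exchange stands apart from the two chlorine-bearing aryl groups, with a 2.2-fold higher number from compound 2 to compound 4 (0.33 log units; beyond the scatter) and a 4.4-fold higher number from compound 1 to compound 4 (0.64 log units; beyond the scatter) as the steps, so across these four compounds both aryl groups with chlorine give lower numbers than both without it, and no compound shown goes against this. Nothing available bears on a cause for this order.

Whether the ethoxy group or the ring nitrogen governs the result stays open, as the two enter together and neither appears alone among the compounds shown. Also open, going by these compounds, is what a 2-aminopyridin-3-yl group or a longer propoxy chain on the pyridine ring would give at this carbon.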